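The compounds below may be only part of what the source reports. "The series", "measured", "known", "first", "only" and "open" are said of these compounds alone.

Measured so far:
compound 1, `CNC(=O)c1cc(C(=O)NC2CC2)cn(Cc2cccc(OC)c2)c1=O`, gives 79 ug/mL in a physicochemical assay for solubility; on this read-out higher numbers stand for higher solubility and lower numbers for lower solubility.
compound 2, `CNC(=O)c1cc(C(=O)NCCCC2CNCCO2)cn(Cc2ccccc2)c1=O`, gives >= 194 ug/mL in this assay, which is a limit of the assay rather than a number.

Compound 2 therefore stands at the top of the readings shown, on the line (the limit of >= 194 ug/mL in this assay, at which 1 of the 2 values shown sits). Compound 1 gives a plain number. Compound 3, `CNC(=O)c1cc(C(=O)NC(C)C)cn(Cc2ccccc2)c1=O`, differs from compound 2 by isopropyl in place of 3-(morpholin-2-yl)propyl on an amide-type nitrogen. Among the compounds with values here, no step between measured compounds is available, so the size of this change can only be guessed. A downward step an at least 2.4-fold lower number from compound 2 to compound 3 (0.38 log units; beyond the scatter) is expected. Compound 3 is estimated at 80 ug/mL, between 35 ug/mL and 180 ug/mL.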

Compound 3, solubility: >= 136 ug/mL
Compound 3: a limit, no number; the forecaster's own chance of this, stated with the estimate: 10%; middle value at least 1.7-fold (0.23 log units) from the limit.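

Within the data shown here, compound 2 and compound 3 each give a limit rather than a number in this assay, so no step between them can be read. As far as these compounds go, whether isopropyl in place of 3-(morpholin-2-yl)propyl changes the read-out, and by how much, stays open.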